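A Sulfonyl Group Replaces Acetyl on the Anilide Nitrogen

The source may report more compounds than this note shows. Statements on the series, on what has been measured and on what is new or still open speak of the compounds shown alone.

Compound 1, `CC(=O)Nc1cccc(-c2cnc3[nH]cc(-c4ccncc4)c3c2)c1`: 34.3 nM
Compound 2, `CC(=O)Nc1cc(N)cc(-c2cnc3[nH]cc(-c4ccncc4)c3c2)c1`: 5.41 nM
Compound 3, `CNc1cccc(-c2cnc3[nH]cc(-c4ccncc4)c3c2)c1`: 31.4 nM

All three compounds share the same core and differ only in the groups carried on the attached phenyl ring. The read-out is an assay on isolated protein for inhibition of high affinity nerve growth factor receptor (Homo sapiens), read by 33P incorporation; a higher number here means a weaker inhibitor, a lower number a stronger inhibitor. Compound 2 gives the lowest number of the three; the step of a 6.3-fold lower number from compound 1 to compound 2 (0.80 log units; beyond the scatter) shows that adding the amino group made the inhibitor modestly stronger, and compound 2 also sits well below compound 3. The step of a 1.1-fold lower number from compound 1 to compound 3 (0.04 log units; within the scatter) shows that swapping acetyl for methyl on the ring nitrogen left the number essentially unchanged.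

Compound 4, `Nc1cc(NS(=O)(=O)c2ccc(F)cc2F)cc(-c2cnc3[nH]cc(-c4ccncc4)c3c2)c1`, differs from compound 2 in one place: (2,4-difluorophenyl)sulfonyl in place of acetyl on a nitrogen on an aromatic ring. Within the data shown here, the step from compound 1 to compound 3 bears on this change, since it also altered the group on that nitrogen, and it was within the scatter; but no measured step covers a group as large as the (2,4-difluorophenyl)sulfonyl one, so the expectation is wider than usual. The expected step of a 1.1-fold higher number from compound 2 to compound 4 (0.04 log units; within the scatter) is therefore small, with no clear direction. Compound 4 is estimated at 6 nM, with a range from 1.5 nM to 25 nM.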

Compound 4, half-maximal inhibitory concentration: 2.97 nM
The estimate for compound 4 lay 2.0-fold (0.31 log units) above the measured number; low and high end bracket the measured number.
By their numbers in this assay, from the lowest: compounds 4 and 2 (each within the scatter of the next); then compounds 3 and 1 (each within the scatter of the next).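

In this assay, the step of a 1.8-fold lower number from compound 2 to compound 4 (0.26 log units; within the scatter) shows that this nitrogen on the aromatic ring can carry (2,4-difluorophenyl)sulfonyl in place of acetyl without the number moving beyond the scatter. The earlier compounds had shown this only for methyl in place of acetyl, a swap to a smaller group, whereas here 11 heavy atoms and a six-membered aromatic ring enter where 3 heavy atoms and no ring leave. Size alone, at least across this one pair, therefore gives no sign of a limit on what this nitrogen can carry in compound 2, and nothing shown here gives a reason for this result.

The compounds shown leave open whether the sulfonyl link or the difluorophenyl ring matters more, a question that a methylsulfonyl group or an unsubstituted phenylsulfonyl group on the same nitrogen would help to separate. They also leave open how the (2,4-difluorophenyl)sulfonyl group behaves on the ring without the amino group, and whether a still longer chain, or a carboxylic acid at its end, would be accepted on this nitrogen.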